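The source may hold more compounds than are shown below. What is called first, only, known or untested is meant among the compounds shown, and "the series" means these compounds.

Compound 1 `O=C1CCC(N2C(=O)c3cccc(Nc4ccccc4)c3C2=O)C(=O)N1` is the plainest member of this small set; in an assay on FRT-Jurkat cells for inhibition of nuclear factor NF-kappa-B complex (Homo sapiens), read by flow cytometry, with a stated time of 24 h, tested at 10 uM (on this read-out higher numbers stand for more inhibition at the one concentration tested (going by the name of the read-out) and lower numbers for less inhibition), compound 1 gives 4%. Compound 2 `CC(C)c1ccc(Nc2cccc3c2C(=O)N(C2CCC(=O)NC2=O)C3=O)cc1`, which carries isopropyl in place of hydrogen on an aromatic carbon, gives 19% in this assay, and this is the higher of the two numbers measured: the step of a number 15 percentage points higher from compound 1 to compound 2 (beyond the scatter) lies beyond the scatter. Compound 3 `CCCc1ccc(Nc2cccc3c2C(=O)N(C2CCC(=O)NC2=O)C3=O)cc1` has not been measured. It differs from compound 2 by propyl in place of isopropyl on an aromatic carbon. Going by the values given here, no measured step exchanges one chain for another of the same size; the only step on record, a number 15 percentage points higher from compound 1 to compound 2 (beyond the scatter), adds a chain where there was none, so it speaks only indirectly. The expected step of a number 2 percentage points lower from compound 2 to compound 3 (within the scatter) is therefore estimated to stay within the scatter. Compound 3 is expected to give about 17% in this assay, in the range from 5% to 30%.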

Compound 3, a percentage reported as inhibition, at one concentration (the size of the read-out at that concentration, not a potency): 23%
Compound 3: the middle estimate sits 6 percentage points below what was measured; low and high end bracket the measured number.
By their numbers in this assay, from the lowest: compound 1; then compounds 2 and 3 (each within the scatter of the next).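

In this assay, exchanging isopropyl for propyl at this place, para to a large group, rearranges the same atoms and gives a number 4 percentage points higher from compound 2 to compound 3 (within the scatter), so the two chains cannot be told apart on this read-out. Set against hydrogen at the same place, propyl also gives a clear rise, a number 19 percentage points higher from compound 1 to compound 3 (beyond the scatter), which shows that the gain seen earlier is not tied to isopropyl alone. Nothing measured here offers a reason for these numbers.

Going by these compounds, whether a longer chain such as butyl, or a group carrying an amine or a carboxylic acid, would raise or lower the inhibition at this place remains open. Each number also comes from one concentration only, so how potent any of these compounds is stays unknown.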